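A few compounds are considered here, and "the series" means these few. Any claim that something is new, unique, unknown or untested is made for them only; others in the source may bear on it.

In a functional assay on SMMC-7721 cells (Homo sapiens) for inhibition, read by CCK-8 assay, with a stated time of 72 h, tested at 8 uM (a lower number here means less inhibition of growth, a higher number more inhibition of growth at the concentration tested), compound 1 (`Nc1ccccc1NC(=O)/C=C/c1ccc(CSc2ccc(Cl)cc2)cc1`) gives 16.5% as the lowest of three numbers. Compound 3 (`Nc1ccccc1NC(=O)c1ccc(CSc2nccc(C(F)(F)F)n2)cc1`) gives 80.6% and compound 2 (`Nc1ccccc1NC(=O)c1ccc(CSc2cccc(F)c2)cc1`) gives 83% in the same read-out. The gaps from compound 1 to compound 3 and to compound 2 both lie beyond the scatter. Compound 4 (`CC(C)(C)c1ccc(SCc2ccc(/C=C/C(=O)Nc3ccccc3N)cc2)cc1`) keeps the core of compound 1 and changes in one place: tert-butyl in place of chloro on an aromatic carbon with tert-butyl in place of chloro on an aromatic carbon, para to a large group. Among the compounds with values here, no measured pair isolates this change, and compound 2 and compound 3 do not share that core. The expectation therefore rests on compound 1 alone, at 16.5% in this series. An estimated step of a number 3.5 percentage points higher from compound 1 to compound 4 (within the scatter) is expected, small, upward and not beyond the scatter. For compound 4 the estimate is 20% with an expected range of 5% to 42% at the tested concentration.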

Compound 4, percent growth inhibition at one concentration: 23.6%
Compound 4: the middle estimate sits 3.6 percentage points below what was measured; measured number inside the range.
By their numbers in this assay, from the lowest: compounds 1 and 4 (each within the scatter of the next); then compounds 3 and 2 (each within the scatter of the next).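

In this assay, tert-butyl in place of chloro on an aromatic carbon, para to a large group, gives a number 7.1 percentage points higher from compound 1 to compound 4 (within the scatter). At this place on the core of compound 1, the 4-chlorophenyl and 4-(tert-butyl)phenyl forms therefore cannot be told apart, although the entering group has 4 heavy atoms and the leaving group 1.

Still open, on these data alone, is whether an amine, a carboxylic acid or a methoxy group at this place would read differently, and whether this change behaves alike on the cores of compound 2 and compound 3. No measurement at hand offers an explanation for this result.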